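Another aryl swap on a shared core

A few compounds are considered here, and "the series" means these few. Any claim that something is new, unique, unknown or untested is made for them only; others in the source may bear on it.

Going by the values given here, in a functional assay on U-87MG ATCC cells for inhibition, with U-87 MG (Homo sapiens) as the target, read by MTT assay, with a stated time of 72 h (on this read-out higher numbers stand for weaker inhibition and lower numbers for stronger inhibition), compound 1 `Cc1ccc(C)c(C(Nc2ccccn2)c2ccc3cccnc3c2O)c1` gives 13800 nM and compound 2 `Oc1c(C(Nc2ccccn2)c2ccc(Cl)cc2)ccc2cccnc12` gives 10600 nM, so compound 2 stands level with its only neighbour, within the usual scatter. The next change leads to compound 3 `Cc1cc(C)c(C(Nc2ccccn2)c2ccc3cccnc3c2O)c(C)c1`: 2,4,6-trimethylphenyl in place of 4-chlorophenyl on a saturated chain carbon bound to an aromatic carbon and a nitrogen on an aromatic ring, with 2,4,6-trimethylphenyl in place of 4-chlorophenyl on a saturated chain carbon bound to an aromatic carbon and a nitrogen on an aromatic ring. Among the compounds with values here, the one measured swap at this place, a 1.3-fold lower number from compound 1 to compound 2 (0.11 log units; within the scatter), stayed within the scatter, so no step beyond the scatter is expected here. The expected change is a 1.1-fold higher number from compound 2 to compound 3 (0.05 log units; within the scatter). For compound 3 the estimated value is 12000 nM, with a range of 6000 nM to 24000 nM.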

Compound 3, half-maximal inhibitory concentration: 10000 nM
Estimate against measurement, compound 3: 1.2-fold (0.08 log units) above; low and high end bracket the measured number.
By their numbers in this assay, from the lowest: compounds 3, 2 and 1 (each within the scatter of the next).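

At this position a third aryl group again leaves the read-out unmoved: this assay gives a 1.1-fold lower number from compound 2 to compound 3 (0.03 log units; within the scatter) and a 1.4-fold lower number from compound 1 to compound 3 (0.14 log units; within the scatter). Even the change from 4-chlorophenyl, with 7 heavy atoms including chlorine, to 2,4,6-trimethylphenyl, with 9 heavy atoms all carbon, stays inside the scatter. Nothing available here offers an explanation for this flat result.

All three groups shown are six-membered aromatic rings of carbon only. On these data alone, whether a ring carrying an amine or a carboxylic acid, or a plain alkyl chain in place of the ring, would move the number beyond the scatter stays open.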